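A Benzyl Group Replaces Ethoxy on Compound 1

The source may hold more compounds than are shown below. What is called first, only, known or untested is meant among the compounds shown, and "the series" means these compounds.

Of the compounds shown here, three have been tested in a functional assay on MCF7 cells (Homo sapiens) for antiproliferative activity, read by MTT assay, with a stated time of 72 h; a higher number here means a weaker inhibitor, a lower number a stronger inhibitor. Compound 1, `CCOc1ccccc1OCCSC(=S)N[C@H]1CCOC1=O`, carries an ethoxy group on its aromatic ring. In this assay compound 1 gives only a limit, > 64000 nM, so no actual number is known for it. Compound 3, `C=CCc1ccc(OCCSC(=S)N[C@H]2CCOC2=O)c(OC)c1`, likewise reaches only a limit in this assay, > 64000 nM. Compound 2, `CC(C)(C)c1ccc(/C=C/C(=O)c2ccc(OCC(=O)N[C@H]3CCOC3=O)cc2)cc1`, is built on a different framework, and in this assay compound 2 gives 16400 nM. Compound 1 thus stands at the weak end of what is known: the limit of > 64000 nM in this assay, at which 2 of the 3 values shown sit.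

Compound 4, `O=C1OCC[C@@H]1NC(=S)SCCOc1ccccc1Cc1ccccc1`, is the untested candidate. It differs from compound 1 in one place: benzyl in place of ethoxy on an aromatic carbon. Among the measured compounds shown here, no pair of measured compounds isolates this change, so its effect is unknown from the data at hand. The expectation for compound 4 is that it remains a weak inhibitor, with 50000 nM, somewhere between 15000 nM and 150000 nM. The step this estimate means, an at least 1.2-fold lower number from compound 1 to compound 4 (0.10 log units; that floor lies within the scatter), is expected to be no larger than the usual scatter, and a second limit is the likelier outcome.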

Compound 4, half-maximal inhibitory concentration: 39500 nM
Compound 4: the middle estimate sits 1.3-fold (0.10 log units) above what was measured; the measured number falls inside the stated range.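

On this aromatic carbon, ortho to a large group, benzyl gives compound 4 an actual number in this assay, which ethoxy did not give compound 1. The change amounts to an at least 1.6-fold lower number from compound 1 to compound 4 (0.20 log units; that floor lies within the scatter), so a real gain in potency is not established, although the true step could be larger. The uncertainty lies with the starting point, since the value for compound 1 is only a limit: the limit of > 64000 nM in this assay, at which 2 of the 4 values shown sit.

On these data alone, what remains open is whether the ring of the benzyl group matters here or simply the larger group, a question that a cyclohexylmethyl group or a longer chain in the same place could help answer. As far as these compounds go, it is also open whether an amine or a carboxylic acid on that ring would move compound 4 in either direction.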